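One substitution on an aromatic ring: compound 2 to compound 3

The source may hold more compounds than are shown below. What is called first, only, known or untested is meant among the compounds shown, and "the series" means these compounds.

Compound 1, `Cc1ccc([N+](=O)[O-])cc1S(=O)(=O)N1CCC(c2cnn3ccc(Br)cc23)C1`: > 1000 nM (a limit of the assay)
Compound 2, `N#Cc1ccc(F)c([S+]([O-])c2nc(-c3cnn4ccc(Br)cc34)cs2)c1`: > 1000 nM (a limit of the assay)

Of the compounds shown here, two have been measured in an assay on isolated protein for inhibition of phosphatidylinositol 4,5-bisphosphate 3-kinase catalytic subunit beta isoform (Homo sapiens); on this read-out higher numbers stand for weaker inhibition and lower numbers for stronger inhibition. For compound 1 the read-out is only a limit, > 1000 nM. For compound 2 the read-out is likewise only a limit, > 1000 nM. Compound 2 therefore stands at the limit of the assay, where both shown values sit: the limit of > 1000 nM in this assay, at which 2 of the 2 values shown sit. Among the compounds with values here, no step between two measured compounds is known, so nothing sets the scale of what a single change does in this assay here.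

Compound 3, `CN(C)CCN(C)c1ccc(C#N)cc1[S+]([O-])c1nc(-c2cnn3ccc(Br)cc23)cs1`, differs from compound 2 in one place: (2-(dimethylamino)ethyl)(methyl)amino in place of fluoro on an aromatic carbon. The expected step in this assay is a modest gain, close to the scatter: a step that the limit leaves unreadable from compound 2 to compound 3. Compound 3 is accordingly estimated at 1500 nM, within a range from 300 nM to 8000 nM, with a fair chance that the assay again reports only a limit.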

Compound 3, half-maximal inhibitory concentration: 4340 nM
Compound 3: the middle estimate sits 2.9-fold (0.46 log units) below what was measured; low and high end bracket the measured number.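

In this assay, no step can be read from compound 2 to compound 3, since the value of compound 2 is only a limit: the limit of > 1000 nM in this assay, at which 2 of the 3 values shown sit.

The compounds shown leave open both the size and the direction of what (2-(dimethylamino)ethyl)(methyl)amino in place of fluoro on an aromatic carbon does to inhibition in this assay.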